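The source may hold more compounds than are shown below. What is called first, only, known or untested is meant among the compounds shown, and "the series" means these compounds.

Compound 1 `CC(C)[C@H](NC(=O)COc1cccc2ccccc12)C(=O)N[C@@H](CC(=O)O)C(=O)COc1cccc2ccccc12` carries a naphthalen-1-yl group on an oxygen on a saturated carbon at one end of its chain. In a functional assay on Jurkat cells (Homo sapiens) (on this read-out lower numbers stand for stronger inhibition and higher numbers for weaker inhibition), compound 1 gives > 100000 nM, which is a limit of the assay rather than a number. Compound 2 `CC(C)[C@H](NC(=O)COc1cccc2ccccc12)C(=O)N[C@@H](CC(=O)O)C(=O)COc1ccc(C#N)cc1` differs from compound 1 in one place, with 4-cyanophenyl in place of naphthalen-1-yl. In this assay compound 2 gives > 100000 nM, again a limit and not a number. The step that the two limits leave unreadable from compound 1 to compound 2 therefore cannot be read, because of the limit of > 100000 nM in this assay, at which 2 of the 2 values shown sit. Compound 3 `CC(C)[C@H](NC(=O)COc1cccc2ccccc12)C(=O)N[C@@H](CC(=O)O)C(=O)COc1cc(F)cc(F)c1` has not yet been measured; it differs from compound 1 as follows: 3,5-difluorophenyl in place of naphthalen-1-yl on an oxygen on a saturated carbon. For the measured compounds named here, the only measured step that replaces the same naphthalen-1-yl group left no readable size, so there is no measured ground for expecting a change in this assay beyond the scatter. The most likely outcome for compound 3 is expected to be another limit, so the step of a number no higher from compound 1 to compound 3 (the limit leaves the size open) is estimated as essentially none. For compound 3 the expected value in this assay is 100000 nM, within a range from 20000 nM to 300000 nM.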

Compound 3, half-maximal inhibitory concentration: > 100000 nM
Compound 3 was reported as a limit (the forecaster's own chance of this, stated with the estimate: 85%); the middle value sits exactly at the limit.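

In this assay compound 3 gives > 100000 nM, again a limit and not a number, so neither its step from compound 1 nor its step from compound 2 can be read: the limit of > 100000 nM in this assay, at which 3 of the 3 values shown sit.

The compounds shown leave open whether naphthalen-1-yl, 4-cyanophenyl and 3,5-difluorophenyl differ at all in how strongly they inhibit.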